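A few compounds are considered here, and "the series" means these few. Any claim that something is new, unique, unknown or untested is made for them only; others in the source may bear on it.

Working notes on the series. The shared core appears in compound 1 `CC(C(=O)NCc1ccc(C(F)(F)F)cc1N1CCCC1)c1ccc(NS(C)(=O)=O)c(F)c1`, compound 2 `CC1CCN(c2cc(C(F)(F)F)ccc2CNC(=O)C(C)c2ccc(NS(C)(=O)=O)c(F)c2)CC1` and compound 3 `CC(C(=O)NCc1ccc(C(F)(F)F)cc1F)c1ccc(NS(C)(=O)=O)c(F)c1`. In an assay on CHO cells for antagonist activity at transient receptor potential cation channel subfamily V member 1 (Homo sapiens), read by FLIPR (a higher number here means a weaker inhibitor, a lower number a stronger inhibitor), compound 1 gives 2.3 nM, compound 2 gives 0.9 nM, and compound 3 gives 68.7 nM, the highest of the three numbers. The measured steps run a 2.6-fold lower number from compound 1 to compound 2 (0.41 log units; beyond the scatter), a 30-fold higher number from compound 1 to compound 3 (1.48 log units; beyond the scatter) and a 76-fold higher number from compound 2 to compound 3 (1.88 log units; beyond the scatter). Compound 4 `CC(C(=O)NCc1ccc(C(F)(F)F)cc1-c1ccc(C(C)(C)C)cc1)c1ccc(NS(C)(=O)=O)c(F)c1` carries the change (4-(tert-butyl)phenyl in place of fluoro on an aromatic carbon). Going by the values given here, two measured steps bear on it, those that exchange the fluoro of compound 3 for a larger group: read in reverse, a 30-fold higher number from compound 1 to compound 3 (1.48 log units; beyond the scatter) and a 76-fold higher number from compound 2 to compound 3 (1.88 log units; beyond the scatter) show that either of the two nitrogen rings in place of fluoro brought a large fall in the number. Among the compounds with values here, no measured pair shows an aromatic ring of carbon only in place of fluoro, so the size of the step is less certain than its direction. A large step downward is nonetheless expected, a 14-fold lower number from compound 3 to compound 4 (1.14 log units; beyond the scatter). Compound 4 is expected to give 5 nM in this assay, with a range from 1 nM to 30 nM.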

Compound 4, inhibition constant: 1.1 nM
Compound 4: middle estimate off by 4.5-fold (0.66 log units), on the high side, within the range that was stated.
By their numbers in this assay, from the lowest: compounds 2 and 4 (each within the scatter of the next); then compound 1; then compound 3.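

At this position, on an aromatic carbon meta to the trifluoromethyl group, a ring nitrogen joined to the aromatic carbon is not required for a large fall in the number in this assay: 4-(tert-butyl)phenyl, an aromatic ring of carbon only, in place of fluoro gives a large step (a 62-fold lower number from compound 3 to compound 4 (1.80 log units; beyond the scatter)). Exchanged for 4-methylpiperidin-1-yl, the same group gives a step within the scatter (a 1.2-fold higher number from compound 2 to compound 4 (0.09 log units; within the scatter)), while exchanged for pyrrolidin-1-yl it gives a modest one (a 2.1-fold lower number from compound 1 to compound 4 (0.32 log units; beyond the scatter)). Nothing available explains these steps.

Open, on these data alone, is how much of the fall belongs to the aromatic ring and how much to its tert-butyl group. Plain phenyl, or a phenyl ring carrying a carboxylic acid or an amine in place of tert-butyl, would separate the two.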